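The compounds below may be only part of what the source reports. "The series", "measured", "known", "first", "only" and "open" are said of these compounds alone.

Series built on a shared core: compound 1 `CC(C)C[C@H](N)CN(C(=O)[C@@H]1C[C@H]1c1ccccc1)c1ccc(-c2ccncc2)cc1` carries pyridin-4-yl, compound 2 `CC(C)C[C@H](N)CN(C(=O)[C@@H]1C[C@H]1c1ccccc1)c1ccc(-c2ccoc2)cc1` furan-3-yl and compound 3 `CC(C)C[C@H](N)CN(C(=O)[C@@H]1C[C@H]1c1ccccc1)c1ccc(C2=CCCC2)cc1` cyclopent-1-en-1-yl. In a functional assay for agonist activity at G protein-coupled receptor 88 (Homo sapiens), read by HTRF and cAMP accumulation (on this read-out higher numbers stand for an effect only at larger amounts of compound and lower numbers for an effect already at smaller amounts), compound 1 gives 13000 nM, compound 2 gives 2000 nM and compound 3 gives 1200 nM. Compound 3 holds the lowest number of the three, but its gap to compound 2, a 1.7-fold lower number from compound 2 to compound 3 (0.22 log units; within the scatter), is within the scatter, so no order between those two is claimed; the steps of an 11-fold lower number from compound 1 to compound 3 (1.03 log units; beyond the scatter) and a 6.5-fold lower number from compound 1 to compound 2 (0.81 log units; beyond the scatter) both lie beyond it.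

Compound 4 `Cc1ccc(-c2ccc(N(C[C@@H](N)CC(C)C)C(=O)[C@@H]3C[C@H]3c3ccccc3)cc2)cc1` is the next step: 4-methylphenyl in place of cyclopent-1-en-1-yl on an aromatic carbon. Among the measured compounds shown here, no measured pair shows this exchange of a five-membered non-aromatic ring for a six-membered aromatic ring of carbon only. The nearest guides are the steps from compound 1 and compound 2 to compound 3, which show that two of the three groups tried at this place give numbers within the scatter of each other, and only compound 1 stands apart. For compound 4 a change in this assay of a 1.1-fold lower number from compound 3 to compound 4 (0.04 log units; within the scatter) is therefore expected, not beyond the scatter. Compound 4 is estimated at 1100 nM, with a range from 300 nM to 4500 nM.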

Compound 4, half-maximal effective concentration: 360 nM
Compound 4: middle estimate off by 3.1-fold (0.49 log units), on the high side; the range from low to high includes it.
By their numbers in this assay, from the lowest: compound 4; then compounds 3 and 2 (each within the scatter of the next); then compound 1.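

In this assay the 4-methylphenyl group separates from the earlier groups at this place on the aromatic carbon: both a 3.3-fold lower number from compound 3 to compound 4 (0.52 log units; beyond the scatter) and a 5.6-fold lower number from compound 2 to compound 4 (0.74 log units; beyond the scatter) lie beyond the scatter, whereas compound 2 and compound 3 could not be ordered. The span across the four groups widens to a 36-fold lower number from compound 1 to compound 4 (1.56 log units; beyond the scatter) and shows that this position, para to a large group, accepts the larger group with 7 heavy atoms and still gives the lowest number of the series. Nothing available bears on the cause of this step.

Open, on these data alone, is how much of the step belongs to the methyl group and how much to the six-membered aromatic ring itself. Also open, as far as these compounds go, is how an amine, a carboxylic acid or a longer chain in place of that methyl would read at this position.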